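The source may hold more compounds than are shown below. What is called first, only, known or untested is meant among the compounds shown, and "the series" means these compounds.

Working notes on the series.

Compound 1 `Fc1ccc(-c2csc(N/N=C/c3ccc(Cl)cc3Cl)n2)cc1` and compound 2 `Cc1ccc(-c2csc(N/N=C/c3ccc(Cl)cc3Cl)n2)cc1` share a core and differ by methyl in place of fluoro on an aromatic carbon. In a functional assay, read by spectrophotometry, with a stated time of 15 min, tested at 60 ug/mL (a higher number here means a stronger effect of the compound at the concentration tested, a lower number a weaker effect), compound 1 gives 92.4%, and compound 2 gives 83.2%; the step is a number 9.2 percentage points lower from compound 1 to compound 2 (within the scatter). Compound 3 `Fc1ccc(-c2csc(N/N=C/c3cccs3)n2)cc1` carries the fluoro of compound 1 on a different core; the difference between the two cores is not broken down here. In this assay compound 3 gives 90.3%, within the scatter of compound 1 and also within the scatter of compound 2.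

Compound 4 `Cc1ccc(-c2csc(N/N=C/c3cccs3)n2)cc1` is not yet measured. It differs from compound 3 by methyl in place of fluoro on an aromatic carbon, the same change that leads from compound 1 to compound 2, and it occurs twice among the compounds shown. Because the earlier step is a number 9.2 percentage points lower from compound 1 to compound 2 (within the scatter), the step from compound 3 to compound 4 is expected to be of similar size, estimated as a number 8.3 percentage points lower from compound 3 to compound 4 (within the scatter) in this assay. Compound 4 is accordingly estimated at 82%, expected to fall between 70% and 92%.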

Compound 4, a percentage reported as inhibition, at one concentration (the size of the read-out at that concentration, not a potency): 84.4%
The estimate for compound 4 lay 2.4 percentage points below the measured number; low and high end bracket the measured number.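

On the second core, methyl in place of fluoro on an aromatic carbon reads in this assay as a number 5.9 percentage points lower from compound 3 to compound 4 (within the scatter). Set beside the earlier step, the step on the second core does not differ from the one on the first: the same change on two cores in this assay, a number 9.2 percentage points lower (within the scatter) from compound 1 to compound 2 and a number 5.9 percentage points lower (within the scatter) from compound 3 to compound 4, 3.3 percentage points apart, within the scatter of two such steps

In these two matched pairs the change therefore carries from one core to the other without a difference that can be told from the scatter, but neither step lies beyond the scatter, so this does not establish that the change has a real effect on either core, and two cores say nothing about a third.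

The compounds shown hold only fluoro or methyl on the six-membered aromatic ring, so it remains open how an amine, a carboxylic acid or a longer chain at that place would read. From the compounds shown here alone, it also remains open whether any group there would give a step beyond the scatter on either core.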